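The source may hold more compounds than are shown below. What is called first, only, known or untested is meant among the compounds shown, and "the series" means these compounds.

Measured compounds:
Compound 1 `Cc1nc(NCCCNS(C)(=O)=O)nc2ccc(NC(=O)/C=C/c3ccc(OC(F)(F)F)cc3)cc12` — 32 nM
Compound 2 `CCCC1(O)CCN(c2nc(C)c3cc(NC(=O)/C=C/c4ccc(Cl)cc4)ccc3n2)CC1` — 91 nM

Two compounds share the same cinnamamide-bearing core and have been run in a functional assay on CHO-K1 cells for antagonist activity at melanin-concentrating hormone receptor 1 (Homo sapiens), read by inositol phosphate accumulation, with stated times of 10 min and 45 min; on this read-out higher numbers stand for weaker inhibition and lower numbers for stronger inhibition. Compound 1 gives 32 nM, the lower of the two numbers, while compound 2 gives 91 nM; the gap from compound 1 to compound 2 lies beyond the usual scatter, so compound 1 stands as the stronger inhibitor of the pair. Within the data shown here, no single-point step links the two, since they differ both in the group on the aromatic carbon between the two ring nitrogen atoms and in the substituent on the cinnamoyl ring.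

Compound 3 `Cc1nc(N2CCC(N3CCNC3=O)CC2)nc2ccc(NC(=O)/C=C/c3ccc(OC(F)(F)F)cc3)cc12` has not yet been measured. It keeps the trifluoromethoxy cinnamamide of compound 1 and differs from it in one place: 4-(2-oxoimidazolidin-1-yl)piperidin-1-yl in place of (3-(methanesulfonamido)propyl)amino on an aromatic carbon. The open chain carrying the methanesulfonamide gives way to a two-ring arrangement.

Among the measured compounds shown here, with no measured pair to anchor this exact change, the expected step in this assay from compound 1 to compound 3 is small, on the order of the scatter or a little beyond it toward a higher number, estimated as a 1.6-fold higher number from compound 1 to compound 3 (0.19 log units; within the scatter). Compound 3 is therefore expected to give about 50 nM, within a range from 12 nM to 200 nM.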

Compound 3, half-maximal inhibitory concentration: 31 nM
For compound 3 the middle estimate is 1.6-fold (0.21 log units) above the measured one, and the stated range covers the measured number.
By their numbers in this assay, from the lowest: compounds 3 and 1 (each within the scatter of the next); then compound 2.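

In this assay, placing 4-(2-oxoimidazolidin-1-yl)piperidin-1-yl in place of (3-(methanesulfonamido)propyl)amino on the aromatic carbon between two ring nitrogen atoms gives a 1.0-fold lower number from compound 1 to compound 3 (0.01 log units; within the scatter), so the two groups cannot be told apart on this read-out. Among these compounds, this is the first single-place change at this position, and it shows that, with the trifluoromethoxy cinnamamide held fixed, neither the open chain nor the methanesulfonamide is required for a number of this size, since a group with two non-aromatic rings and no sulfur serves equally well in this pair. The data shown offer no explanation for why two such different groups read alike.

Still open, as far as these compounds go, is how far this freedom extends: whether a plain piperidin-1-yl without the cyclic urea, a chain carrying a carboxylic acid, or a chain longer than the propyl one would read the same on this core. Among the compounds shown here, it also remains open whether 4-(2-oxoimidazolidin-1-yl)piperidin-1-yl would behave the same way alongside the chlorine-bearing cinnamoyl ring of compound 2, which stays linked to the others by no single-place step.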